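Replacing the 4-fluorophenyl group of compound 2

The source may hold more compounds than are shown below. What is called first, only, known or untested is meant among the compounds shown, and "the series" means these compounds.

Measured so far in a functional assay on CNE-2 cells (Homo sapiens) for antiproliferative activity, read by sulforhodamine B assay, with a stated time of 48 h (on this read-out lower numbers stand for stronger inhibition and higher numbers for weaker inhibition), on two compounds:
Compound 1 `COc1ccc(OC)c(/C=C/C(=O)/C=C(O)/C=C/c2cc(OC)ccc2OC)c1` gives 14700 nM
Compound 2 `COc1cccc(/C=C/C(=O)C(=Cc2ccc(F)cc2)C(=O)/C=C/c2cccc(OC)c2OC)c1OC` gives 610 nM

Compound 2 at 610 nM holds the lower of the two numbers, and compound 1 at 14700 nM sits above it by a gap beyond the scatter. Compound 3 `COc1ccc(C=C(C(=O)/C=C/c2cccc(OC)c2OC)C(=O)/C=C/c2cccc(OC)c2OC)cc1OC` keeps the structure of compound 2 except for one group, with 3,4-dimethoxyphenyl in place of 4-fluorophenyl on a double-bonded chain carbon bound to a double-bonded chain carbon.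

For the measured compounds named here, no two measured compounds differ in only one place, so this change has no direct precedent. In this assay a small shift toward a higher number is expected, probably none beyond the scatter, with compound 2 at 610 nM as the only close anchor for that expectation. The expected change is a 1.3-fold higher number from compound 2 to compound 3 (0.12 log units; within the scatter) and it remains an estimate with wide margins. Compound 3 is estimated at 800 nM (expected range 250 nM to 2500 nM).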

Compound 3, half-maximal inhibitory concentration: 280 nM
Estimate against measurement, compound 3: 2.9-fold (0.46 log units) above; the measured number falls inside the stated range.
By their numbers in this assay, from the lowest: compound 3; then compound 2; then compound 1.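

In this assay, for the compounds shown here, the first one-place comparison comes from placing 3,4-dimethoxyphenyl in place of 4-fluorophenyl on a double-bonded chain carbon bound to a double-bonded chain carbon, which gives a 2.2-fold lower number from compound 2 to compound 3 (0.34 log units; beyond the scatter). This shows that the fluorine is not needed for activity at this position and that a group with more heavy atoms and more hydrogen-bond acceptors is accepted there, with a modest gain rather than a loss; compound 1 differs from both in more than one place, so it adds nothing to this reading. No measurement on hand bears on why the number moves in this direction.

With one step at this position, the compounds shown cannot separate the loss of the fluorine from the gain of the two methoxy groups, nor show whether both methoxy groups contribute. Going by these compounds, whether the trend extends is also open: a plain phenyl, a 4-methoxyphenyl or a 4-(dimethylamino)phenyl group at the same carbon would each test a different part of that question.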